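The source may hold more compounds than are shown below. What is called first, only, known or untested is meant among the compounds shown, and "the series" means these compounds.

Compound 1 `O=C(c1oc(C(F)(F)F)nc1-c1cccc(F)c1)N1CCN(c2cccc(Cl)c2)CC1` gives "not active" (no number reported) in a functional assay on HL-60 cells (Homo sapiens) for inhibition, read by MTT assay, with a stated time of 72 h; on this read-out lower numbers stand for stronger inhibition and higher numbers for weaker inhibition. Compound 2 `Cc1nc(-c2cccc(F)c2)c(C(=O)N2CCN(c3cccc(Cl)c3)CC2)o1` gives 33.7 nM. Compound 3 `COc1cc(OC)cc(N2CCN(C(=O)c3oc(C)nc3-c3cccc(F)c3)CC2)c1` gives 28.2 nM.

Among these, compound 2 has the highest of the two numbers in this assay; its nearest neighbour is compound 3, separated by a 1.2-fold lower number from compound 2 to compound 3 (0.08 log units; within the scatter). Compound 4 `Cc1nc(-c2ccccc2F)c(C(=O)N2CCN(c3cccc(Cl)c3)CC2)o1` differs from compound 2 by 2-fluorophenyl in place of 3-fluorophenyl on an aromatic carbon. Within the data shown here, the only measured step, a 1.2-fold lower number from compound 2 to compound 3 (0.08 log units; within the scatter), concerns the aryl group on the amine nitrogen in a ring rather than the fluorophenyl, so no measured step bears directly on this change, and compound 1 offers no number to compare. Compound 4 is therefore expected to sit close to compound 2, with an estimated step of a 1.2-fold higher number from compound 2 to compound 4 (0.07 log units; within the scatter), not beyond the scatter. The estimate for compound 4 is 40 nM, ranging from 12 nM to 130 nM.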

Compound 4, half-maximal inhibitory concentration: 39.4 nM
Compound 4: the middle estimate sits 1.0-fold (0.01 log units) above what was measured; low and high end bracket the measured number.
By their numbers in this assay, from the lowest: compounds 3, 2 and 4 (each within the scatter of the next).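

In this assay, 2-fluorophenyl in place of 3-fluorophenyl, on the aromatic carbon next to the ring nitrogen, gives a 1.2-fold higher number from compound 2 to compound 4 (0.07 log units; within the scatter). Among these compounds, this is the only measured step at this position, and it shows that the two fluorophenyl isomers cannot be told apart here, whereas the earlier step concerned only the aryl group on the amine nitrogen. Nothing available explains this result. Still open, going by these compounds, is whether a plain phenyl, or a phenyl carrying a methoxy group or an amine, would read alike at this position. Also open, on these data alone, is whether 2-fluorophenyl behaves the same alongside 3,5-dimethoxyphenyl.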